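This account rests on a few compounds, and the source may have more. Where it says the series, first, only, none or still open, it means among the compounds named here.

Compound 2 `CC(=O)Nc1ccc(CCS(=O)(=O)N2CCC3(CC2)N=C(C2CCCCC2)NC3=O)c(C)c1` was examined in an ADME assay on microsomes from liver (Homo sapiens) for metabolic stability, read by LC-MS, using NADPH, with a stated time of 30 min, tested at 1 uM (a higher number here means faster removal of the compound, a lower number slower removal), where compound 2 gives 46 uL/min. Its number is the highest of the three available, although compound 1 `Cc1cc(N(C)C(N)=O)cc(C)c1CCS(=O)(=O)N1CCC2(CC1)N=C([C@H]1CC[C@H](C)CC1)NC2=O` with 45 uL/min and compound 3 `CC(=O)Nc1cc(C)c(CCS(=O)(=O)N2CCC3(CC2)N=C(C2CCCCC2)NC3=O)c(C)c1` with 39 uL/min both fall within the scatter of it. Among the compounds with values here, the one step between measured compounds that differ in a single place, a 1.2-fold lower number from compound 2 to compound 3 (0.07 log units; within the scatter), involved methyl in place of hydrogen on an aromatic carbon and did not move the number beyond the scatter. Compound 4 `O=C1NC(C2CCCCC2)=NC12CCN(S(=O)(=O)CCc1cccc3ccccc13)CC2` differs from compound 2 by naphthalen-1-yl in place of 4-acetamido-2-methylphenyl on a saturated chain carbon, two bonds along the chain from a sulfonyl sulfur. Within the data shown here, no measured pair covers a change of this kind: the only step on hand touches a single methyl, whereas here the whole 4-acetamido-2-methylphenyl leaves and naphthalen-1-yl enters, so that step offers little guidance. Compound 4 is therefore expected to stay near the common level of the measured compounds, with the step of a 1.2-fold higher number from compound 2 to compound 4 (0.08 log units; within the scatter) expected. Compound 4 is estimated at 55 uL/min, in a range from 25 uL/min to 120 uL/min in this assay.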

Compound 4, intrinsic clearance in a liver preparation (reported as CLH), per the amount of preparation that the assay uses in the Homo sapiens assay: 300 uL/min
Compound 4: middle estimate off by 5.5-fold (0.74 log units), on the low side; measured number above the stated range.
By their numbers in the Homo sapiens assay, from the lowest: compounds 3, 1 and 2 (each within the scatter of the next); then compound 4.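

This position on a saturated chain carbon, two bonds along the chain from a sulfonyl sulfur, is not indifferent to what it carries: in the Homo sapiens assay, naphthalen-1-yl in place of 4-acetamido-2-methylphenyl gives a 6.5-fold higher number from compound 2 to compound 4 (0.81 log units; beyond the scatter), whereas the earlier methyl step stayed within the scatter. The same exchange also separates the pair in a physicochemical assay for solubility, read by HPLC, in simulated intestinal fluid, tested at 1 mM (on this read-out lower numbers stand for lower solubility and higher numbers for higher solubility), where compound 2 gives 400 ug/mL and compound 4 gives 3.1 ug/mL. The faster removal of compound 4 thus comes with a far lower solubility: the measured solubility of compound 2, 400 ug/mL, and of compound 4, 3.1 ug/mL, a 130-fold lower number (2.11 log units; beyond the scatter)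

The compounds shown do not separate the loss of the acetamido group from the gain of the second aromatic ring, as both change in this single exchange. They also leave open whether a plain phenyl, or a naphthalen-1-yl carrying an amine, would stay near compound 2 in either read-out.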